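Swapping an Oxadiazole for Ethoxy: Cytotoxicity Expectations

The compounds below may be only part of what the source reports. "The series", "measured", "known", "first", "only" and "open" are said of these compounds alone.

Compound 3 `Cc1nnc(-c2cccc(-c3ccc(C(=O)N(Cc4cccc(OCCCCCC(=O)O)c4)C(C)C)cc3)c2)o1` is one of three compounds already examined in an ADME assay on HEK293 cells (Homo sapiens) for cytotoxicity, read by CellTiter-Glo and resazurin assay, with a stated time of 72 h; on this read-out higher numbers stand for an effect only at larger amounts of compound and lower numbers for an effect already at smaller amounts. In this assay compound 3 gives > 26000 nM, which is a limit of the assay rather than a number. Compound 1 `CC(C)N(Cc1cccc(OCCCCCC(=O)O)c1)C(=O)c1ccc(-c2ccncc2)cc1` gives > 26000 nM in this assay, again a limit. Compound 2 `CC(C)COc1cccc(-c2ccc(C(=O)N(Cc3cccc(OCCCCCC(=O)O)c3)C(C)C)cc2)c1` gives > 26000 nM in this assay, also a limit. Because all three values sit at the limit of > 26000 nM in this assay, at which 3 of the 3 values shown sit, the steps a step that the two limits leave unreadable from compound 1 to compound 2, a step that the two limits leave unreadable from compound 1 to compound 3 and a step that the two limits leave unreadable from compound 2 to compound 3 have no readable size, so where compound 3 stands relative to the other two cannot be told beyond the shared limit.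

Compound 4 `CCOc1cccc(-c2ccc(C(=O)N(Cc3cccc(OCCCCCC(=O)O)c3)C(C)C)cc2)c1` has not yet been measured in this assay. It differs from compound 3 in a single place: ethoxy in place of 5-methyl-1,3,4-oxadiazol-2-yl on an aromatic carbon. The nearest measured step, a step that the two limits leave unreadable from compound 2 to compound 3, exchanged an isobutoxy group for the same oxadiazole at that aromatic carbon and gave nothing readable, since both ends were limits. With every measured value at the limit, no step beyond the scatter is expected here, and the step that the limit leaves unreadable from compound 3 to compound 4 is expected to be none beyond the scatter. Compound 4 is therefore estimated at 30000 nM, within a range from 15000 nM to 80000 nM, and will most likely be reported as a limit as well.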

Compound 4, half-maximal effective concentration: > 20800 nM
Compound 4 gave a limit, no number; the forecaster's own chance of this, stated with the estimate: 85%; the middle value is on the limit's open side.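

Compound 4 also gives a limit rather than a number, so none of its steps from compound 1, compound 2 or compound 3 can be read. The compounds shown leave open at what amount any of the four has an effect in this assay, and whether exchanging pyridin-4-yl, isobutoxy, ethoxy or 5-methyl-1,3,4-oxadiazol-2-yl changes that amount.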